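This account rests on a few compounds, and the source may have more. Where it says the series, first, only, none or still open, it means among the compounds named here.

Working notes on the series, step from compound 1 to compound 3.

For the measured compounds named here, compound 1 `CC(C)CCn1nc(-c2cccs2)c(O)c(C2=NS(=O)(=O)c3ccccc3N2)c1=O` is one of two compounds measured in an in vitro ADME assay on microsomes from liver (Homo sapiens) for metabolic stability, tested at 5 uM; a lower number here means that the compound disappears faster, a higher number that the compound lasts longer; in this assay compound 1 gives 0.2 h. Going by the values given here, of the two numbers it is the smaller one, but the only comparison is compound 2 `CC(C)CCn1nc(-c2cccs2)c(O)c(C2=NS(=O)(=O)c3cc(OCC(N)=O)ccc3N2)c1=O`, which in this assay gives 0.383 h, and the step of a 1.9-fold higher number from compound 1 to compound 2 (0.28 log units; within the scatter) does not separate the two.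

Compound 3 `CC(C)CCn1nc(-c2cccs2)c(O)c(C2=NS(=O)(=O)c3cc(OC(C)(C)C(N)=O)ccc3N2)c1=O` arises from compound 1 by 1-carbamoyl-1-methylethoxy in place of hydrogen on an aromatic carbon. Among the compounds with values here, the one measured step that bears on this change is the one from compound 1 to compound 2, where a carbamoylmethoxy group entered on an aromatic carbon in place of hydrogen and produced a 1.9-fold higher number from compound 1 to compound 2 (0.28 log units; within the scatter), a shift within the scatter. Within the data shown here, the change to compound 3 puts a 1-carbamoyl-1-methylethoxy group in that role instead; no measured pair shows how such a group behaves in this assay, so the expectation rests on the carbamoylmethoxy case alone.

On that basis no step beyond the scatter is expected; the estimated step of a 1.7-fold higher number from compound 1 to compound 3 (0.22 log units; within the scatter) is small. Compound 3 is expected to give about 0.33 h, within a range from 0.16 h to 0.7 h.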

Compound 3, half-life: 0.35 h
The estimate for compound 3 lay 1.1-fold (0.03 log units) below the measured number, and the stated range covers the measured number.
By their numbers in this assay, from the lowest: compounds 1, 3 and 2 (each within the scatter of the next).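

With 1-carbamoyl-1-methylethoxy in place of hydrogen on the aromatic carbon, this assay shows a 1.8-fold higher number from compound 1 to compound 3 (0.24 log units; within the scatter) for this substitution, so this position now carries a second ether group next to the carbamoylmethoxy case, and neither step separates a substituted compound from the unsubstituted one. For the compounds shown here, exchanging carbamoylmethyl for 1-carbamoyl-1-methylethyl on the same oxygen gives a 1.1-fold lower number from compound 2 to compound 3 (0.04 log units; within the scatter) and is the first direct comparison of the two side chains; on these numbers, the chains cannot be told apart in this assay and compound 1, compound 2 and compound 3 all lie within the scatter of each other. No accompanying measurement offers an account of these numbers.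

The compounds shown leave open whether a carboxylic acid, an amine or a longer chain on this oxygen, in place of the carbamoyl-bearing side chains, would produce a step beyond the scatter in this assay and so give this position a readable effect. They also leave open how a carbamoylmethoxy group would behave on the other carbons of the same six-membered aromatic ring.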